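A few compounds are considered here, and "the series" means these few. Any claim that something is new, unique, unknown or untested is made for them only; others in the source may bear on it.

Of the compounds shown here, two have so far been measured in an assay for inhibition of Indoleamine 2,3-dioxygenase 1 (Homo sapiens), with stated times of 10 min and 60 min, tested at 10 uM; a lower number here means a weaker effect, a higher number a stronger effect of the compound at the concentration tested. Compound 1, `FC(F)(F)c1cc(NC[C@H]2CCCCN2)c2cn[nH]c2c1`, gives 19% in this assay. Compound 2, `CNC(=O)c1cccc(CNc2cc(C(F)(F)F)cc3[nH]ncc23)c1`, gives 33% in this assay, the higher of the two numbers, and its nearest neighbour, compound 1, lies lower by a gap beyond the usual scatter.

Compound 3, `FC(F)(F)c1cc(NCc2cccc(Br)c2)c2cn[nH]c2c1`, is not yet measured. It differs from compound 2 in one place: bromo in place of methylcarbamoyl on an aromatic carbon. The methylcarbamoyl, which carries one hydrogen-bond donor and one hydrogen-bond acceptor, leaves, and a single bromine enters on the same aromatic carbon.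

Going by the values given here, no step between measured compounds shows what such a change does here. The step expected from compound 2 to compound 3 in this assay is a small decrease, a number 8 percentage points lower from compound 2 to compound 3 (within the scatter), hardly beyond the scatter. For compound 3 the expected inhibition in this assay is 25%, with a range from 5% to 50%.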

Compound 3, a percentage reported as inhibition, at one concentration (the size of the read-out at that concentration, not a potency): 23%
Estimate against measurement, compound 3: 2 percentage points above, within the range that was stated.
By their numbers in this assay, from the lowest: compounds 1, 3 and 2 (each within the scatter of the next, the first and the last beyond it).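

In this assay, the methylcarbamoyl, with its hydrogen-bond donor and acceptor, can give way to a single bromine on this aromatic carbon without a change that stands out from the scatter (a number 10 percentage points lower from compound 2 to compound 3 (within the scatter)). The new compound also links a second pair: 3-bromophenyl in place of piperidin-2-yl on the chain leaves the read-out within the scatter (a number 4 percentage points higher from compound 1 to compound 3 (within the scatter)), so neither single change can be told apart from repeat variation at this one concentration. Nothing measured here explains these small steps.

Open, on these data alone, is whether any group on this aromatic carbon, such as a carboxylic acid or an amine, would move the inhibition beyond the scatter. Also open, as far as these compounds go, is how a longer chain in place of the single carbon bound to the nitrogen would behave.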